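A few compounds are considered here, and "the series" means these few. Any claim that something is new, unique, unknown or untested is made for them only; others in the source may bear on it.

Compound 1 `Cc1ccc(S(=O)(=O)c2nc3ccccc3nc2N2CCc3ccccc3C2)cc1` is the starting point of this series. In a functional assay on KB cells (Homo sapiens) for cytotoxicity, read by MTT assay, with a stated time of 72 h (on this read-out lower numbers stand for stronger inhibition and higher numbers for weaker inhibition), compound 1 gives 32100 nM. Compound 2 `COc1ccc(S(=O)(=O)c2nc3ccccc3nc2N2CCc3ccccc3C2)cc1` carries the change methoxy in place of methyl on an aromatic carbon on the same core. In this assay compound 2 gives > 50000 nM, which is a limit of the assay and not a number. The step therefore reads as an at least 1.5-fold higher number from compound 1 to compound 2 (0.19 log units; that floor lies within the scatter), a floor that rests on (the limit of > 50000 nM in this assay, at which 1 of the 3 values shown sits), so the true size of this change is not pinned down here.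

Compound 3 `Cc1ccc(S(=O)(=O)c2nc3ccccc3nc2N2CCCC(O)C2)cc1` differs from compound 1 in the core side, by 3-hydroxypiperidin-1-yl in place of 1,2,3,4-tetrahydroisoquinolin-2-yl on an aromatic carbon. In this assay compound 3 gives 6080 nM, and the step is a 5.3-fold lower number from compound 1 to compound 3 (0.72 log units; beyond the scatter), the lowest number among the two measured values.

Compound 4 `COc1ccc(S(=O)(=O)c2nc3ccccc3nc2N2CCCC(O)C2)cc1` is the still unmeasured partner of compound 3, made from it by methoxy in place of methyl on an aromatic carbon. The place of this change is the same, word for word, as in the step from compound 1 to compound 2, so it is the same change applied to a different core. Because the earlier step of an at least 1.5-fold higher number from compound 1 to compound 2 (0.19 log units; that floor lies within the scatter) was a rise that ran into the limit, a rise of at least similar size is expected here, and the step from compound 3 to compound 4 is estimated at a 2.5-fold higher number from compound 3 to compound 4 (0.39 log units; beyond the scatter). For compound 4 in this assay the expected value is 15000 nM, with a range from 6000 nM to 50000 nM.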

Compound 4, half-maximal inhibitory concentration: 2120 nM
For compound 4 the middle estimate is 7.1-fold (0.85 log units) above the measured one; measured number below the stated range.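

With a 2.9-fold lower number from compound 3 to compound 4 (0.46 log units; beyond the scatter), methoxy in place of methyl does not carry over unchanged from the core of compound 1 to the core of compound 3 in this assay: the same change on two cores in this assay, an at least 1.5-fold higher number (0.19 log units; that floor lies within the scatter) from compound 1 to compound 2 and a 2.9-fold lower number (0.46 log units; beyond the scatter) from compound 3 to compound 4, at least 4.4-fold (0.65 log units) apart, beyond the scatter of two such steps

Read the other way, 3-hydroxypiperidin-1-yl in place of 1,2,3,4-tetrahydroisoquinolin-2-yl lowers the number on both the methyl and the methoxy partners, but by clearly different amounts, with an at least 23-fold lower number from compound 2 to compound 4 (1.37 log units; beyond the scatter) set against a 5.3-fold lower number from compound 1 to compound 3 (0.72 log units; beyond the scatter): the same change on two cores in this assay, a 5.3-fold lower number (0.72 log units; beyond the scatter) from compound 1 to compound 3 and an at least 23-fold lower number (1.37 log units; beyond the scatter) from compound 2 to compound 4, at least 4.4-fold (0.65 log units) apart, beyond the scatter of two such steps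

The value of compound 2, > 50000 nM, is a limit of the assay and not a number, so both gaps are floors whose true size stays unknown, and this single pair of cores gives neither a general rule for the series nor a reason for the difference: the limit of > 50000 nM in this assay, at which 1 of the 4 values shown sits.

The compounds shown leave open whether the same dependence on the core appears with other amines in that place, such as piperidine without the hydroxyl, morpholine or piperazine. They also leave open how other groups on the aromatic ring, such as ethoxy, chlorine or a carboxylic acid, would behave on these two cores.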